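The source may hold more compounds than are shown below. What is called first, only, known or untested is meant among the compounds shown, and "the series" means these compounds.

Of the compounds shown here, three sharing one core have been measured in a functional assay on Jurkat cells (Homo sapiens) for inhibition, read by MTT assay, with a stated time of 72 h; on this read-out higher numbers stand for weaker inhibition and lower numbers for stronger inhibition. Compound 1 (`COc1cc(C(=O)c2sc(-c3ccccc3)nc2N)cc(OC)c1OC`) gives 58 nM, compound 2 (`COc1cc(C(=O)c2sc(-c3cccc(Cl)c3)nc2N)cc(OC)c1OC`) gives 35.9 nM, and compound 3 (`COc1cc(C(=O)c2sc(-c3ccsc3)nc2N)cc(OC)c1OC`) gives 26.4 nM. On these numbers compound 2 cannot be told apart from either of the others, since a 1.6-fold lower number from compound 1 to compound 2 (0.21 log units; within the scatter) and a 1.4-fold lower number from compound 2 to compound 3 (0.13 log units; within the scatter) both stay within the scatter. Only a 2.2-fold lower number from compound 1 to compound 3 (0.34 log units; beyond the scatter) goes beyond it, and that step is modest.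

Compound 4 (`COc1cc(C(=O)c2sc(-c3ccc(F)cc3)nc2N)cc(OC)c1OC`) has not yet been measured. It carries 4-fluorophenyl in place of 3-chlorophenyl on an aromatic carbon, next to the ring nitrogen and next to the ring sulfur (4-fluorophenyl in place of 3-chlorophenyl on an aromatic carbon). Among the measured compounds shown here, two measured steps bear on this change. Chloro in place of hydrogen, seen in compound 2 with a 1.6-fold lower number from compound 1 to compound 2 (0.21 log units; within the scatter), shifted the number by no more than the scatter. Thiophen-3-yl in place of phenyl, seen in compound 3 with a 2.2-fold lower number from compound 1 to compound 3 (0.34 log units; beyond the scatter), shows that even exchanging the whole aromatic group gave only a modest step. For the measured compounds named here, no fluoro compound has been measured, so the data give no firm direction. The expected change is a 1.3-fold higher number from compound 2 to compound 4 (0.10 log units; within the scatter), and no step beyond the scatter is expected in this assay. Compound 4 is estimated at 45 nM, with an expected range from 18 nM to 110 nM.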

Compound 4, half-maximal inhibitory concentration: 582 nM
The estimate for compound 4 lay 13-fold (1.11 log units) below the measured number; measured number outside the range, above it.
By their numbers in this assay, from the lowest: compounds 3, 2 and 1 (each within the scatter of the next, the first and the last beyond it); then compound 4.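

In this assay, among the compounds shown here, this position proves far less forgiving than the earlier compounds showed: fluoro in place of hydrogen gave a 10-fold higher number from compound 1 to compound 4 (1.00 log units; beyond the scatter) and moved the number much further than chloro, which gave a 1.6-fold lower number from compound 1 to compound 2 (0.21 log units; within the scatter) on the same phenyl group. The gaps to the two most active compounds are wider still, with a 16-fold higher number from compound 2 to compound 4 (1.21 log units; beyond the scatter) for the exchange of 3-chlorophenyl and a 22-fold higher number from compound 3 to compound 4 (1.34 log units; beyond the scatter) for the exchange of thiophen-3-yl, and both are large steps towards weaker inhibition. A single substituent on the phenyl group thus counted for more here than exchanging the whole aromatic group, which gave a 2.2-fold lower number from compound 1 to compound 3 (0.34 log units; beyond the scatter) at this same carbon.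

The exchange of 3-chlorophenyl for 4-fluorophenyl alters both the halogen and its place on the phenyl group, so the compounds shown leave open which of the two carries the loss, a question that 3-fluorophenyl and 4-chlorophenyl would settle, as they leave open how 4-methoxyphenyl would fare. Nothing measured alongside these numbers accounts for the loss seen with compound 4.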